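Swapping the Amide Tail of Compound 1 for an Ester

The source may hold more compounds than are shown below. What is called first, only, known or untested is meant among the compounds shown, and "the series" means these compounds.

Compound 1 `CCCC(=O)OCSc1ccccc1C(=O)NCCCC(N)=O` was examined in an ADME assay on CEM-SS cells (Homo sapiens) for cytotoxicity, read by XTT assay, with a stated time of 6 days (on this read-out lower numbers stand for higher toxicity in this test and higher numbers for lower toxicity in this test), where compound 1 gives 56.6 uM. This is the highest of the two numbers recorded. The other measured compound, compound 2 `CCCC(=O)OCSc1ccccc1C(=O)Nc1cccc(C(N)=O)c1`, gives 17.5 uM in this assay, and the gap between the two lies beyond the scatter. Going by the values given here, the two measured compounds differ in more than one place, so no single documented step connects them.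

Compound 3 `CCCC(=O)OCSc1ccccc1C(=O)NCC(=O)OC` has not yet been measured in this assay. It differs from compound 1 as follows: methoxycarbonyl in place of 2-carbamoylethyl on a saturated chain carbon bound to an amide-type nitrogen. Among the compounds with values here, nothing among the measured compounds speaks directly to this exchange. Within the data shown here, the measured pair shows only that a change on the amide side of the shared core can move the number beyond the scatter. With no closer comparison at hand, the step from compound 1 is expected to be modest and not clearly in either direction. The estimate for compound 3 is 45 uM, between 20 uM and 100 uM. That estimate corresponds to an expected step of a 1.3-fold lower number from compound 1 to compound 3 (0.10 log units; within the scatter).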

Compound 3, half-maximal toxic concentration: 27.3 uM
Compound 3: middle estimate off by 1.6-fold (0.22 log units), on the high side, within the range that was stated.
By their numbers in this assay, from the lowest: compounds 2 and 3 (each within the scatter of the next); then compound 1.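

In this assay, going by these compounds alone, the exchange of 2-carbamoylethyl for methoxycarbonyl on a saturated chain carbon bound to an amide-type nitrogen gives a 2.1-fold lower number from compound 1 to compound 3 (0.32 log units; beyond the scatter) and so provides the first single-place step in this set, a modest one toward higher toxicity in this test. It shows that this position alone can move the number beyond the scatter, with the shared core untouched and a saturated chain still attached to the amide-type nitrogen, which the earlier pair, differing in more than one place, could not show. No measured information accounts for the step, which therefore stands as an observation about these two compounds only.

Read one bond further out, the change is from 3-carbamoylpropyl to (methoxycarbonyl)methyl, so it alters the chain length and the end group together, and the compounds shown leave open which of these matters here. A longer chain ending in the same methoxycarbonyl would address the chain length, while a carboxylic acid in its place would probe the end group, and neither is among the compounds shown.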